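From furan-3-yl to cyclohexyl on a shared core

The compounds below may be only part of what the source reports. "The series", "measured", "known", "first", "only" and "open" are said of these compounds alone.

In an ADME assay on Vero cells (Chlorocebus sabaeus) for cytotoxicity, read by MTT assay, with a stated time of 96 h (a higher number here means that more compound is tolerated, a lower number that less compound is tolerated), compound 1 (`COc1ccc(-c2nc3cc(/C(C)=N/NC(N)=O)ccc3[nH]2)cc1`) has "not determined" (no result reported) as its entry and so offers no result. Compound 2 (`C/C(=N\NC(N)=O)c1ccc2[nH]c(-c3ccoc3)nc2c1`) gives > 100000 nM in this assay and this is a limit, not a number. Compound 3 (`C/C(=N\NC(N)=O)c1ccc2[nH]c(C3CCCCC3)nc2c1`) carries cyclohexyl in place of furan-3-yl on an aromatic carbon. Going by the values given here, no measured step guides this change, so only a modest move in this assay toward less compound tolerated is expected. The estimated move is an at least 1.4-fold lower number from compound 2 to compound 3 (0.15 log units; that floor lies within the scatter) and it remains a rough expectation. Compound 3 is expected at 70000 nM with an estimated range of 20000 nM to 200000 nM in this assay once measured.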

Compound 3, half-maximal cytotoxic concentration: > 100000 nM
Compound 3 gave a limit, no number; the forecaster's own chance of this, stated with the estimate: 55%; middle value at least 1.4-fold (0.15 log units) away from the limit.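

No step can be read from compound 2 to compound 3, whose entries in this assay are both limits, not numbers: the limit of > 100000 nM in this assay, at which 2 of the 3 values shown sit.

On these data alone, whether furan-3-yl or cyclohexyl is better tolerated remains open, as does where either compound's actual value lies.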